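Aryl swap on the butanamide chain of the shared core

A few compounds are considered here, and "the series" means these few. Any claim that something is new, unique, unknown or untested is made for them only; others in the source may bear on it.

Compound 1 `COc1cccc(CCCC(=O)Nc2nc3ccccc3c(=O)s2)c1` is the only numbered point in an assay on CHO cells for displacement of a labelled ligand from adenosine receptor A3 (Homo sapiens), read by scintillation counting, with a stated time of 60 min; a higher number here means a weaker inhibitor, a lower number a stronger inhibitor: compound 1 gives 382 nM. Compound 2 `O=C(/C=C/c1cccc(Cl)c1)Nc1nc2ccccc2c(=O)s1` gives > 1000 nM in this assay, which is a limit of the assay and not a number, as the limit of > 1000 nM in this assay, at which 1 of the 2 values shown sits, records. Compound 3 `O=C(CCCc1ccc(Cl)c(Cl)c1)Nc1nc2ccccc2c(=O)s1` carries 3,4-dichlorophenyl in place of 3-methoxyphenyl on a saturated chain carbon, three bonds along the chain from a carbonyl carbon. No measured step of this kind is shown, so no direction can be read from the data; a change of the aryl substituents alone is expected to move this assay by no more than the scatter, and the expected step of a 1.0-fold higher number from compound 1 to compound 3 (0.02 log units; within the scatter) reflects that. Compound 3 is therefore estimated at 400 nM, within 150 nM to 1500 nM.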

Compound 3, inhibition constant: > 1000 nM
Compound 3 ended at the assay's limit (the forecaster's own chance of this, stated with the estimate: 25%); at least 2.5-fold (0.39 log units) between middle value and limit.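

The aryl group on the butanamide chain is not a silent position in this assay: 3,4-dichlorophenyl in place of 3-methoxyphenyl gives an at least 2.6-fold higher number from compound 1 to compound 3 (0.41 log units; beyond the scatter). Compound 3 gives > 1000 nM, which is a limit and not a number. Compound 1 remains the only numbered point, and the upper edge of the series is marked only by this: the limit of > 1000 nM in this assay, at which 2 of the 3 values shown sit.

Going by these compounds, whether the step follows from losing the methoxy or gaining the chlorines stays open. Also open, on these data alone, is how an unsubstituted phenyl or a longer chain would read in this assay.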